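Ethyl in place of cyclopropyl on an aromatic nitrogen

The source may hold more compounds than are shown below. What is called first, only, known or untested is meant among the compounds shown, and "the series" means these compounds.

Of the compounds shown here, two have numbers so far. In a functional assay on A549 cells (Homo sapiens) for antiproliferative activity, read by MTT assay, with a stated time of 72 h (a higher number here means a weaker inhibitor, a lower number a stronger inhibitor), compound 1 (`CCn1cc(C(=O)O)c(=O)c2cc(F)c(N3CCN(C(=N)NS(=O)(=O)c4ccccc4Cl)CC3)cc21`) gives 71 nM. In the same read-out compound 2 (`N=C(NS(=O)(=O)c1ccc(Cl)cc1)N1CCN(c2cc3c(cc2F)c(=O)c(C(=O)O)cn3C2CC2)CC1`) gives 71 nM, which places compound 2 level with compound 1, within the scatter.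

The next compound is compound 3 (`CCn1cc(C(=O)O)c(=O)c2cc(F)c(N3CCN(C(=N)NS(=O)(=O)c4ccc(Cl)cc4)CC3)cc21`). It differs from compound 2 in one place, with ethyl in place of cyclopropyl on an aromatic nitrogen. That nitrogen belongs to a six-membered aromatic ring with 1 nitrogen, part of a fused or bridged system of two rings.

Going by the values given here, no measured pair shows this change alone, so the expectation has little to stand on. It rests on the two values in hand, compound 1 at 71 nM and compound 2 at 71 nM. In this assay no step beyond the scatter is expected, and no direction is favoured. The expected step is a 1.1-fold higher number from compound 2 to compound 3 (0.02 log units; within the scatter).

Compound 3 is estimated at 75 nM, with an expected range of 30 nM to 190 nM.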

Compound 3, half-maximal inhibitory concentration: 71 nM
For compound 3 the middle estimate is 1.1-fold (0.02 log units) above the measured one, within the range that was stated.
By their numbers in this assay, from the lowest: compounds 1, 2 and 3 (each within the scatter of the next).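

In this assay the change on the aromatic nitrogen gives no change at the digits printed from compound 2 to compound 3 (within the scatter), so ethyl and cyclopropyl are not told apart at this position, at least with 4-chlorophenyl on the sulfonyl sulfur. Placing 4-chlorophenyl in place of 2-chlorophenyl on the sulfonyl sulfur gives no change at the digits printed from compound 1 to compound 3 (within the scatter), so the two chlorophenyl groups are not told apart either, at least with ethyl on the aromatic nitrogen; compound 1 and compound 2 differ in two places, and only compound 3 allows each change to be read alone. Nothing at hand offers an explanation for either step.

From the compounds shown here alone, whether the aromatic nitrogen tolerates more than these two small groups remains open, since a longer chain such as n-butyl or a benzyl group there could still separate from ethyl and cyclopropyl. On the sulfonyl side, the reading covers only two placements of chlorine, so 3-chlorophenyl, or a phenyl group carrying an amine or a methoxy group in place of the chlorine, could show whether this end of the series is as flat in this assay as these steps suggest.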